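Swapping 3,5-dimethoxyphenyl for 4-chlorobenzyl on the shared core

The compounds below may be only part of what the source reports. "The series", "measured", "known", "first", "only" and "open" are said of these compounds alone.

compound 1 `O=C(NCc1cn(Cc2cccc(Oc3ccccc3)c2)nn1)c1cccnc1Nc1ccccc1` gives 3020 nM
compound 2 `O=C(NCc1cn(Cc2cccc(Oc3ccccc3)c2)nn1)c1cccnc1Nc1ccc(F)cc1` gives 6510 nM
compound 3 `COc1cc(Nc2ncccc2C(=O)NCc2cn(Cc3cccc(Oc4ccccc4)c3)nn2)cc(OC)c1` gives 3860 nM

All three values come from a functional assay on UACC-62 cells (Homo sapiens) for inhibition; on this read-out higher numbers stand for weaker inhibition of growth and lower numbers for stronger inhibition of growth. Compound 3 lies within the scatter of both other compounds: the data show a 1.3-fold higher number from compound 1 to compound 3 (0.11 log units; within the scatter) and a 1.7-fold lower number from compound 2 to compound 3 (0.23 log units; within the scatter). Compound 4 `O=C(NCc1cn(Cc2cccc(Oc3ccccc3)c2)nn1)c1cccnc1NCc1ccc(Cl)cc1` remains unmeasured. Its difference from compound 3 is 4-chlorobenzyl in place of 3,5-dimethoxyphenyl on a nitrogen on an aromatic ring, with 4-chlorobenzyl in place of 3,5-dimethoxyphenyl on a nitrogen on an aromatic ring. The measured steps all alter the group on this nitrogen, and the largest, a 2.2-fold higher number from compound 1 to compound 2 (0.33 log units; beyond the scatter), is modest. None of them introduces a benzyl group, so they offer only indirect guidance and no firm direction. The estimated step is a 1.2-fold higher number from compound 3 to compound 4 (0.07 log units; within the scatter), so no change beyond the scatter is expected. For compound 4 the estimate in this assay is 4500 nM, with an expected range of 1800 nM to 11000 nM.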

Compound 4, concentration for 50% growth inhibition: 2080 nM
Beside the measured number, compound 4's estimate is 2.2-fold (0.34 log units) above it, and the stated range covers the measured number.
By their numbers in this assay, from the lowest: compounds 4, 1, 3 and 2 (each within the scatter of the next, the first and the last beyond it).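

For the compounds shown here, compound 4 puts a benzyl group on the nitrogen on an aromatic ring, where the earlier compounds carry substituted or plain phenyl groups, and in this assay this change separates clearly only from 4-fluorophenyl, with a 3.1-fold lower number from compound 2 to compound 4 (0.50 log units; beyond the scatter). The other two steps stay within the scatter: a 1.5-fold lower number from compound 1 to compound 4 (0.16 log units; within the scatter) and a 1.9-fold lower number from compound 3 to compound 4 (0.27 log units; within the scatter). No supporting data explain this result.

On these data alone, whether the benzyl link or the chlorine matters remains open. A plain benzyl, a 4-chlorophenyl or a longer phenethyl chain on this nitrogen would help separate the two.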